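The source may hold more compounds than are shown below. What is called first, only, known or untested is meant among the compounds shown, and "the series" means these compounds.

Compound 1 `CC(C)OC(=O)N1CCC(Oc2ncnc3c2CCN3c2ccc(S(C)(=O)=O)cc2F)CC1` gives 91%
Compound 2 `CC(C)OC(=O)N1CCC(Oc2ncnc3c2CCN3c2ccc(C#N)cc2F)CC1` gives 134%
Compound 3 `CC(C)OC(=O)N1CCC(Oc2ncnc3c2CCN3c2ccc(-c3cccn3C)cc2F)CC1` gives 44%

These three compounds share one core and differ only in the group on an aromatic carbon of the outer ring. In a functional assay on CHO-K1 cells with Glucose-dependent insulinotropic receptor (Homo sapiens) as the target, read by a luciferase reporter, with a stated time of 5 h (a lower number here means a smaller maximal response, a higher number a larger maximal response), compound 1 stands second highest of the three numbers. The replacement of methylsulfonyl by cyano gives a number 43 percentage points higher from compound 1 to compound 2 (beyond the scatter), while the replacement by 1-methyl-1H-pyrrol-2-yl gives a number 47 percentage points lower from compound 1 to compound 3 (beyond the scatter); between the two outer compounds the gap is a number 90 percentage points lower from compound 2 to compound 3 (beyond the scatter). All three steps therefore concern the same place, the aromatic carbon.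

Compound 4 `CC(C)(C)COC(=O)N1CCC(Oc2ncnc3c2CCN3c2ccc(S(C)(=O)=O)cc2F)CC1` has not yet been measured. It differs from compound 1 in a different place altogether: neopentyl in place of isopropyl on an oxygen next to a carbonyl group The group on the aromatic carbon, methylsulfonyl, stays as in compound 1. Going by the values given here, none of the measured steps touches the oxygen next to a carbonyl group, so no measured step bears directly on this change, and the only guide is that the part of the molecule that drove the large measured steps is left unchanged.

On that basis the step for compound 4 is expected to be a number 1 percentage points lower from compound 1 to compound 4 (within the scatter), within the scatter. Compound 4 is therefore estimated at 90% in this assay, with a range from 60% to 125%.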

Compound 4, largest response reached (reported as percent of maximum), in percent of the reference or control that the assay uses: 80%
For compound 4 the middle estimate is 10 percentage points above the measured one; the range from low to high includes it.
By their numbers in this assay, from the lowest: compound 3; then compound 4; then compound 1; then compound 2.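

The oxygen next to a carbonyl group is not a silent place: in this assay, neopentyl in place of isopropyl gives a number 11 percentage points lower from compound 1 to compound 4 (beyond the scatter), even though the methylsulfonyl group on the aromatic carbon stays as it was. Going by these compounds alone, the earlier compounds varied only that aromatic carbon, so this is the first sign that the other end of the molecule also affects the maximal response, although this step is clearly smaller than a number 43 percentage points higher from compound 1 to compound 2 (beyond the scatter) or a number 47 percentage points lower from compound 1 to compound 3 (beyond the scatter). No supporting measurement is available to explain the drop that comes with the two extra carbon atoms of neopentyl.

With only isopropyl and neopentyl shown at this oxygen, a single step cannot reveal a trend, and an ethyl group, a cyclobutyl ring or a longer chain such as n-hexyl could each behave differently. From the compounds shown here alone, it also remains open whether neopentyl would lower the response in the same way with the nitrile of compound 2 or the 1-methyl-1H-pyrrol-2-yl group of compound 3 on the aromatic carbon.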